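Methoxy to trifluoromethyl at two placements in the series

The source may report more compounds than this note shows. Statements on the series, on what has been measured and on what is new or still open speak of the compounds shown alone.

Measured in an assay on isolated protein for inhibition of serine/threonine-protein kinase PLK1 (Homo sapiens), read by radiometric assay and 33P incorporation, with a stated time of 40 min, tested at 20 uM, in the presence of a further agent that is not named here; a lower number here means less inhibition, a higher number more inhibition at the concentration tested (going by the name of the read-out):

compound 1 `CCNc1cc(-c2ccc(NC(=O)Nc3ccccc3Cl)cc2C(F)(F)F)ccn1`: 71.6%
compound 2 `CCNc1cc(-c2ccc(NC(=O)Nc3ccccc3Cl)cc2OC)ccn1`: 53.6%
compound 3 `CCNc1cc(-c2ccc(NC(=O)Nc3ccc(OC)cc3)cc2F)ccn1`: 47.1%

Compound 2 and compound 1 differ in one place, (trifluoromethyl in place of methoxy on an aromatic carbon). That step gives a number 18 percentage points higher from compound 2 to compound 1 (beyond the scatter). Compound 3 carries the same core as the others but differs from compound 2 in more than one place; the difference between the two cores is not broken down here. Compound 3 stands lowest of the three numbers, with compound 2 nearest and within the scatter and compound 1 furthest and beyond the scatter.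

Compound 4 `CCNc1cc(-c2ccc(NC(=O)Nc3ccc(C(F)(F)F)cc3)cc2F)ccn1` is not yet measured in this assay. It differs from compound 3 by trifluoromethyl in place of methoxy on an aromatic carbon. This is the same kind of change as from compound 2 to compound 1, not the same change: in the measured pair the group sits ortho to a 2-(ethylamino)pyridin-4-yl group and meta to a large group, whereas in compound 4 it sits para to a large group on the other ring. For the measured compounds named here, the measured step of a number 18 percentage points higher from compound 2 to compound 1 (beyond the scatter) therefore serves only as a loose guide, and a smaller step is expected here, resting on the single measured step and on compound 3 giving 47.1%. The expected step from compound 3 to compound 4 is a number 9.9 percentage points higher from compound 3 to compound 4 (within the scatter). Compound 4 is estimated at 57%, with a range from 42% to 72%.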

Compound 4, a percentage reported as inhibition, at one concentration (the size of the read-out at that concentration, not a potency): 55.8%
For compound 4 the middle estimate is 1.2 percentage points above the measured one; the range from low to high includes it.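

In this assay trifluoromethyl in place of methoxy, para to a large group on the core of compound 3, gives a number 8.7 percentage points higher from compound 3 to compound 4 (within the scatter) and so, taken alone, this step cannot be told apart from no change. Set beside the earlier step on the other core, the size of the change does not differ measurably between the two settings: the same change on two cores in this assay, a number 18 percentage points higher (beyond the scatter) from compound 2 to compound 1 and a number 8.7 percentage points higher (within the scatter) from compound 3 to compound 4, 9.3 percentage points apart, within the scatter of two such steps. This fits a change that carries over from one core to the other, but it does not establish that: there is only one pair per core, the group sits at a different place in each pair, and the second step lies within the scatter, so neither a shared effect nor a dependence on core or placement is shown.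

The compounds shown leave open how a nitrile or a carboxylic acid would read at the place held by trifluoromethyl in compound 4, and whether a longer chain in place of the ethyl of the ethylamino group would move the numbers. On these data alone, all of these readings also stand at one concentration, so how the change affects potency remains open.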